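From Compound 3 to Compound 4: Losing the Hydroxy Group

The source may report more compounds than this note shows. Statements on the series, on what has been measured and on what is new or still open speak of the compounds shown alone.

Of the compounds shown here, three built on a shared core have been measured in a functional assay on T47D cells (Homo sapiens) for inhibition, read by CCK-8 assay, with a stated time of 72 h, tested at 10 uM; on this read-out higher numbers stand for more inhibition of growth at the one concentration tested and lower numbers for less inhibition of growth. Compound 1 `Cc1ccc(NC(=O)C2(C(=O)Nc3ccc(Nc4ncc5cc(C(=O)N(C)C)n(C6CCCC6)c5n4)cc3)CC2)cc1` gives 99.6%, compound 2 `CN(C)C(=O)c1cc2cnc(Nc3ccc(NC(=O)C4(C(=O)Nc5cccc(C(F)(F)F)c5)CC4)cc3)nc2n1C1CCCC1` gives 92.7%, and compound 3 `CN(C)C(=O)c1cc2cnc(Nc3ccc(NC(=O)C4(C(=O)Nc5ccc(O)cc5)CC4)cc3)nc2n1C1CCCC1` gives 95.8%. Compound 3 therefore lies within the scatter of both the others, and the three values cannot be ranked with any confidence.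

Compound 4 `CN(C)C(=O)c1cc2cnc(Nc3ccc(NC(=O)C4(C(=O)Nc5ccccc5)CC4)cc3)nc2n1C1CCCC1` differs from compound 3 at one place, with hydrogen in place of hydroxy on an aromatic carbon, para to a large group: hydrogen in place of hydroxy on an aromatic carbon. This turns 4-hydroxyphenyl into phenyl.

Among the measured compounds shown here, no measured step makes exactly this change, but three alter the same aryl group on the amide-type nitrogen. The account records a number 3.8 percentage points lower from compound 1 to compound 3 (within the scatter), with hydroxy in place of methyl, and a number 3.1 percentage points higher from compound 2 to compound 3 (within the scatter), with 4-hydroxyphenyl in place of 3-(trifluoromethyl)phenyl. It also records a number 6.9 percentage points lower from compound 1 to compound 2 (within the scatter), with 3-(trifluoromethyl)phenyl in place of 4-methylphenyl. All three stay within the scatter, and none of the three compounds goes against this, so no step beyond the scatter is expected in this assay. The expected change is small, a number 0.8 percentage points lower from compound 3 to compound 4 (within the scatter). For compound 4 the estimated value is 95%, with an expected range of 86% to 101%.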

Compound 4, percent growth inhibition at one concentration: 93.9%
Beside the measured number, compound 4's estimate is 1.1 percentage points above it, and the stated range covers the measured number.
By their numbers in this assay, from the lowest: compounds 2, 4, 3 and 1 (each within the scatter of the next).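

With phenyl on the amide-type nitrogen, compound 4 gives the three substituted rings a common point of comparison in this assay: hydrogen in place of hydroxy gives a number 1.9 percentage points lower from compound 3 to compound 4 (within the scatter) and hydrogen in place of trifluoromethyl gives a number 1.2 percentage points higher from compound 2 to compound 4 (within the scatter) while hydrogen in place of methyl gives a number 5.7 percentage points lower from compound 1 to compound 4 (within the scatter). The earlier steps only exchanged one substituent for another, whereas these show that, among the compounds shown, growth inhibition at the one concentration tested does not depend on hydroxy, methyl or trifluoromethyl being present on this ring, since each removal stays within the scatter. No measurement offered here gives a reason for this outcome.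

As far as these compounds go, whether an amine or a carboxylic acid at this place on the ring would move the number beyond the scatter remains open, as does the effect of replacing the phenyl with a longer alkyl chain. From the compounds shown here alone, all four compounds also give high numbers at a single concentration, so it remains open whether they would separate at lower concentrations.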